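Trimethoxyphenyl beta-lactams: nitrophenyl to hydroxy-methoxy-nitrophenyl

This account rests on a few compounds, and the source may have more. Where it says the series, first, only, none or still open, it means among the compounds named here.

Measured so far in a functional assay on MCF7 cells (Homo sapiens) for antiproliferative activity, read by MTT assay, with stated times of 24 h and 72 h; on this read-out higher numbers stand for weaker inhibition and lower numbers for stronger inhibition:
Compound 1, `COc1cc(N2C(=O)[C@@H](Oc3ccccc3)[C@H]2c2cccc([N+](=O)[O-])c2)cc(OC)c1OC`, gives 30000 nM.
Compound 2, `COc1cc(N2C(=O)[C@@H](Oc3ccccc3)[C@H]2c2ccc([N+](=O)[O-])cc2)cc(OC)c1OC`, gives 63000 nM.
Compound 3, `CCOC(=O)/C=C/c1ccc([C@@H]2[C@H](Oc3ccccc3)C(=O)N2c2cc(OC)c(OC)c(OC)c2)cc1`, gives 87000 nM.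

Compound 2 holds the second highest of the three numbers; compound 3 sits within the scatter of it, while compound 1 lies beyond the scatter on the lower side, a 2.1-fold higher number from compound 1 to compound 2 (0.32 log units; beyond the scatter).

Compound 4, `COc1ccc([C@@H]2[C@H](Oc3ccccc3)C(=O)N2c2cc(OC)c(OC)c(OC)c2)c([N+](=O)[O-])c1O`, is the next step: a group of 12 heavy atoms (7 carbon, 1 nitrogen, 4 oxygen; one six-membered aromatic ring of carbon only) in place of a group of 9 heavy atoms (6 carbon, 1 nitrogen, 2 oxygen; one six-membered aromatic ring of carbon only), on a saturated ring carbon.

Going by the values given here, two measured steps touch this ring. Moving the nitro group gave a 2.1-fold higher number from compound 1 to compound 2 (0.32 log units; beyond the scatter), a modest step. Exchanging the nitro for another group on an aromatic carbon gave a 1.4-fold higher number from compound 2 to compound 3 (0.14 log units; within the scatter), within the scatter. Both changes on this ring left the number in a narrow band, so no step beyond the scatter is expected, a 1.1-fold lower number from compound 2 to compound 4 (0.06 log units; within the scatter).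

Compound 4 is therefore estimated at 55000 nM in this assay, expected between 18000 nM and 170000 nM.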

Compound 4, half-maximal inhibitory concentration: 89000 nM
For compound 4 the middle estimate is 1.6-fold (0.21 log units) below the measured one; low and high end bracket the measured number.
By their numbers in this assay, from the lowest: compound 1; then compounds 2, 3 and 4 (each within the scatter of the next).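

In this assay, the larger group on the saturated ring carbon, which brings a hydrogen-bond donor that 4-nitrophenyl lacks, gives a 1.4-fold higher number from compound 2 to compound 4 (0.15 log units; within the scatter), so this fuller substitution does not separate the two compounds. The gap to the 3-nitrophenyl compound remains, with a 3.0-fold higher number from compound 1 to compound 4 (0.47 log units; beyond the scatter), a modest step. Nothing available bears on the cause of either step.

Still open, as far as these compounds go, is whether an amine or a carboxylic acid on this ring would move the number, and whether any change at this position can give more than a modest step.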